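A Change at the Carbon Double-Bonded to Nitrogen

The compounds below may be only part of what the source reports. "The series", "measured", "known", "first", "only" and "open" are said of these compounds alone.

In a functional assay on HT-29 cells (Homo sapiens) for cytotoxicity, read by MTT assay, with a stated time of 72 h (on this read-out higher numbers stand for weaker inhibition and lower numbers for stronger inhibition), compound 2 `CN(C)CCn1cnnc1-c1cc(Oc2ccc(NC(=O)N/N=C/c3cccc(Cl)c3Cl)cc2F)ccn1` gives 130 nM, the lower of the two numbers in hand. Compound 1 `CN(C)CCn1cnnc1-c1cc(Oc2ccc(NC(=O)N/N=C/c3ccccc3)cc2F)ccn1` gives 1120 nM in this assay. Compound 3 `CN(C)CCn1cnnc1-c1cc(Oc2ccc(NC(=O)N/N=C/c3c(O)ccc4ccccc34)cc2F)ccn1` differs from compound 2 by 2-hydroxynaphthalen-1-yl in place of 2,3-dichlorophenyl on a carbon with a double bond to nitrogen. Going by the values given here, the only step bearing on this place, an 8.6-fold lower number from compound 1 to compound 2 (0.94 log units; beyond the scatter), shows that the group on this carbon can shift the number well beyond the scatter. Among the compounds with values here, no measured compound carries the entering group, so the direction is open. A step of a 2.3-fold higher number from compound 2 to compound 3 (0.36 log units; beyond the scatter) toward a weaker number is expected. Compound 3 is estimated at 300 nM, within 60 nM to 1500 nM.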

Compound 3, half-maximal inhibitory concentration: 670 nM
For compound 3 the middle estimate is 2.2-fold (0.35 log units) below the measured one, within the range that was stated.
By their numbers in this assay, from the lowest: compound 2; then compounds 3 and 1 (each within the scatter of the next).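

Placing 2-hydroxynaphthalen-1-yl on this carbon gives a 5.2-fold higher number from compound 2 to compound 3 (0.71 log units; beyond the scatter) in this assay, so the low number of compound 2 does not carry over to this second replacement of phenyl. Measured against phenyl, the same group gives a 1.7-fold lower number from compound 1 to compound 3 (0.22 log units; within the scatter), leaving compound 3 and compound 1 indistinguishable. No evidence is available that accounts for these differences.

The compounds shown leave open whether the low number of compound 2 requires both chlorine atoms. They also leave open how a phenyl carrying a single chlorine, a methoxy group or an amine would stand at this carbon.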